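Exchanging bromo for chloro in compound 3

A few compounds are considered here, and "the series" means these few. Any claim that something is new, unique, unknown or untested is made for them only; others in the source may bear on it.

In a functional assay on A549 cells (Homo sapiens) for antiproliferative activity, read by MTT assay, with a stated time of 48 h (a higher number here means a weaker inhibitor, a lower number a stronger inhibitor), compound 1 `COc1cc(-c2cccc3nc(-c4ccccc4)oc23)cc(OC)c1OC` gives 20300 nM, compound 2 `COc1ccc(-c2nc3cccc(-c4cc(OC)c(OC)c(OC)c4)c3o2)cc1OC` gives 2800 nM and compound 3 `COc1cc(-c2cccc3nc(-c4cccc(Br)c4)oc23)cc(OC)c1OC` gives 2100 nM. Compound 3 and compound 2 cannot be told apart, since the difference is a 1.3-fold lower number from compound 2 to compound 3 (0.12 log units; within the scatter). Both stand clearly apart from the plain phenyl compound. Adding the bromo goes with a 9.7-fold lower number from compound 1 to compound 3 (0.99 log units; beyond the scatter), and the 3,4-dimethoxyphenyl group goes with a 7.3-fold lower number from compound 1 to compound 2 (0.86 log units; beyond the scatter).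

The next compound, compound 4 `COc1cc(-c2cccc3nc(-c4cccc(Cl)c4)oc23)cc(OC)c1OC`, changes only the bromo of compound 3: chloro in place of bromo on an aromatic carbon. The site of this exchange is a six-membered aromatic ring of carbon only, meta to a large group. Among the compounds with values here, no measured step exchanges bromo for chloro, so the evidence is indirect. The step that added bromo, a 9.7-fold lower number from compound 1 to compound 3 (0.99 log units; beyond the scatter), shows that a substituent on this phenyl ring can matter. However, the two quite different groups in compound 2 and compound 3 ended up within the scatter of each other, a 1.3-fold lower number from compound 2 to compound 3 (0.12 log units; within the scatter). A swap this small is therefore not expected to move the number much in this assay. The change expected is a 1.2-fold higher number from compound 3 to compound 4 (0.08 log units; within the scatter), which would be no step beyond the scatter. For compound 4 the estimated value is 2500 nM, with an expected range of 1100 nM to 6000 nM.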

Compound 4, half-maximal inhibitory concentration: > 25000 nM
Compound 4: only a limit was reported (the forecaster's own chance of this, stated with the estimate: 3%); middle value at least 10-fold (1.00 log units) from the limit.
By their numbers in this assay, from the lowest: compounds 3 and 2 (each within the scatter of the next); then compound 1. At a limit, above all of these: compound 4.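

In this assay compound 4 is reported only as a limit: the limit of > 25000 nM in this assay, at which 1 of the 4 values shown sits.

Even so, the exchange of a single atom at this place on the phenyl ring proves far from neutral, with an at least 11-fold higher number from compound 3 to compound 4 (1.07 log units; beyond the scatter), so bromo and chloro cannot be treated as interchangeable here, even though they count the same under every simple tally of heavy atoms, rings, donors and acceptors. The chloro compound also separates from the compound carrying the 3,4-dimethoxyphenyl group, with an at least 8.9-fold higher number from compound 2 to compound 4 (0.95 log units; beyond the scatter), so a substituent on this ring does not in general bring the number down to the level of compound 2 and compound 3. Chloro in place of hydrogen gives an at least 1.2-fold higher number from compound 1 to compound 4 (0.09 log units; that floor lies within the scatter), and since that floor lies within the scatter, the gain that came with bromo is not seen with chloro, and how far compound 4 lies from compound 1 stays unknown.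

The compounds shown do not say whether bromo is a special case, which a fluoro, iodo or methyl group at the same place could test. They also give no reason for so large a step, and they do not show whether bromo keeps its effect when moved elsewhere on the ring.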